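Removing the methoxy from compound 1

This account rests on a few compounds, and the source may have more. Where it says the series, first, only, none or still open, it means among the compounds named here.

Compound 1 `COc1ccccc1/C=C1\CN(CC(=O)O)c2c(C)cccc2C1=O` gives 4.72% in an assay on HL-60 cells for inhibition of glutathione S-transferase P (Homo sapiens), read by spectrophotometry, tested at 20 uM (a lower number here means less inhibition, a higher number more inhibition at the concentration tested (going by the name of the read-out)), the low end of the three numbers in hand, with the other two inside the scatter of it. Compound 2 `COc1cccc(/C=C2\CN(CC(=O)O)c3c(C)cccc3C2=O)c1OC` gives 8.1% and compound 3 `COc1ccc(/C=C2\CN(CC(=O)O)c3c(C)cccc3C2=O)c(OC)c1` gives 11.7%; each differs from compound 1 by a methoxy on an aromatic carbon, and the steps of a number 3.4 percentage points higher from compound 1 to compound 2 (within the scatter) and a number 7 percentage points higher from compound 1 to compound 3 (within the scatter) both stay within the scatter. Compound 4 `Cc1cccc2c1N(CC(=O)O)C/C(=C\c1ccccc1)C2=O` carries the change (hydrogen in place of methoxy on an aromatic carbon). Those two methoxy steps are the only measured ones that bear on it, and neither moved the read-out beyond the scatter. A step of no more than the scatter is therefore expected in this assay, with no reliable direction, a number 0.7 percentage points lower from compound 1 to compound 4 (within the scatter). Compound 4 is expected to give 4%, between -4% and 13%.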

Compound 4, a percentage reported as inhibition, at one concentration (the size of the read-out at that concentration, not a potency): 27.9%
Compound 4: the middle estimate sits 23.9 percentage points below what was measured; the whole stated range lies below it.
By their numbers in this assay, from the lowest: compounds 1, 2 and 3 (each within the scatter of the next); then compound 4.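

In this assay, going by these compounds alone, the change from 2-methoxyphenyl to phenyl gives a number 23.2 percentage points higher from compound 1 to compound 4 (beyond the scatter) and is the first step in this set beyond the scatter. A further methoxy on compound 1 left the read-out within the scatter, so adding a methoxy and removing this one do not behave alike here. Nothing measured on hand accounts for the step.

Open, from the compounds shown here alone, is whether any group at this position would match hydrogen, for instance fluorine, hydroxyl or an amine. Also open, going by these compounds, is whether a single methoxy elsewhere on the phenyl ring would give a similar result.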